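A few compounds are considered here, and "the series" means these few. Any claim that something is new, unique, unknown or untested is made for them only; others in the source may bear on it.

Measured so far:
- compound 1, `CCn1c(SC/C(=N/O)c2ccccc2)nnc1-c1cc(OC)c(OC)c(OC)c1`: 69% in a functional assay on the whole organism (strain albino) for inhibition, with Rattus norvegicus as the target, read by paw edema, with a stated time of 3 h, at a dose of 0.28 mmol/kg by the oral route; on this read-out lower numbers stand for less inhibition and higher numbers for more inhibition at the one dose given (going by the name of the read-out)
- compound 2, `CCn1c(SC/C(=N/O)c2ccccc2)nnc1-c1ccc(OC)c(OC)c1`: 71% in this assay

Compound 1 stands level with compound 2 in this assay; the step of a number 2 percentage points higher from compound 1 to compound 2 (within the scatter) is within the scatter, so neither number can be set above the other.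

Compound 3, `COc1cc(-c2nnc(SC/C(=N/O)c3ccccc3)n2-c2ccccc2)cc(OC)c1OC`, differs from compound 1 by phenyl in place of ethyl on an aromatic nitrogen. Among the measured compounds shown here, no measured step touches this position; the only measured step alters a methoxy on an aromatic carbon and is within the scatter. There is thus no shown basis for a shift in either direction. For compound 3 the expected step in this assay is a number 1 percentage points lower from compound 1 to compound 3 (within the scatter). Compound 3 is estimated at 68%, in the range 50% to 82%.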

Compound 3, a percentage reported as inhibition, in the whole organism at one dose (the size of the read-out at that dose, not a potency): 64%
The estimate for compound 3 lay 4 percentage points above the measured number, and the stated range covers the measured number.
By their numbers in this assay, from the lowest: compounds 3, 1 and 2 (each within the scatter of the next).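

On the aromatic nitrogen of the five-membered ring, phenyl in place of ethyl gives a number 5 percentage points lower from compound 1 to compound 3 (within the scatter) in this assay at the one dose tested. This position therefore accepts a six-membered aromatic ring in place of ethyl with no change that can be told from the scatter. No measurement on hand offers an explanation for this result.

Still open, from the compounds shown here alone, is whether a longer chain such as n-butyl, a benzyl group or a chain ending in an amine or a carboxylic acid at this nitrogen would move the number beyond the scatter. Also open, going by these compounds, is whether phenyl behaves the same way on the core of compound 2.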